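Fluoro for (3-fluorobenzyl)oxy in a hydroxamate series

The source may report more compounds than this note shows. Statements on the series, on what has been measured and on what is new or still open speak of the compounds shown alone.

Compound 1 `C=CC(=O)Nc1cc2c(Nc3ccc(F)c(Cl)c3)ncnc2cc1OCc1cn(CCCCC(=O)NO)nn1`: > 50000 nM
Compound 2 `C=CC(=O)Nc1cc2c(Nc3ccc(OCc4cccc(F)c4)c(Cl)c3)ncnc2cc1OCc1cn(CCCC(=O)NO)nn1`: > 50000 nM
Compound 3 `C=CC(=O)Nc1cc2c(Nc3ccc(OCc4cccc(F)c4)c(Cl)c3)ncnc2cc1OCc1cn(CCC(=O)NO)nn1`: > 50000 nM

All three measured compounds are read in a functional assay on A549 cells (Homo sapiens) for antiproliferative activity, read by MTT assay, with a stated time of 72 h; on this read-out lower numbers stand for stronger inhibition and higher numbers for weaker inhibition. For compound 1 the result > 50000 nM is a limit of the assay, not a number. For compound 2 the result > 50000 nM is likewise a limit. For compound 3 the result > 50000 nM is also a limit. Among the compounds with values here, the one step that can be traced, a step that the two limits leave unreadable from compound 2 to compound 3, therefore gives no readable size; the three values sit together at the limit of > 50000 nM in this assay, at which 3 of the 3 values shown sit.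

Compound 4 `C=CC(=O)Nc1cc2c(Nc3ccc(F)c(Cl)c3)ncnc2cc1OCc1cn(CCCC(=O)NO)nn1` is the unmeasured member. It differs from compound 2 by fluoro in place of (3-fluorobenzyl)oxy on an aromatic carbon. Within the data shown here, no measured step covers this change; compound 1 shares the fluoro group and sits at the same limit, which is all that can be said of it. With every shown value at the limit, compound 4 is expected to stay there as well, so the step that the limit leaves unreadable from compound 2 to compound 4 is expected to be none beyond the scatter. Compound 4 is estimated at 60000 nM, within 20000 nM to 200000 nM.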

Compound 4, half-maximal inhibitory concentration: > 50000 nM
Compound 4: a limit, no number; the forecaster's own chance of this, stated with the estimate: 80%; the middle value is on the limit's open side.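

In this assay compound 4 gives > 50000 nM, which is a limit, not a number. The steps to compound 4 from compound 1 and from compound 2 therefore cannot be read: the limit of > 50000 nM in this assay, at which 4 of the 4 values shown sit.

The compounds shown leave open whether fluoro or (3-fluorobenzyl)oxy, or the chain length, makes any difference in this assay.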